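A few compounds are considered here, and "the series" means these few. Any claim that something is new, unique, unknown or untested is made for them only; others in the source may bear on it.

Compound 1 `CNC(=O)c1cc(C(=O)NCCCC2CNCCO2)cn(Cc2ccccc2)c1=O`, compound 2 `CNC(=O)c1cc(C(=O)NC2CCC2)cn(Cc2ccccc2)c1=O` and compound 3 `CNC(=O)c1cc(C(=O)NCCOC)cn(Cc2ccccc2)c1=O` share one core and differ only in the group on the amide nitrogen. In a physicochemical assay for solubility (on this read-out higher numbers stand for higher solubility and lower numbers for lower solubility), compound 2 gives 28 ug/mL. For compound 1 the read-out is a limit of the assay, >= 194 ug/mL. For compound 3 it is likewise a limit, >= 164 ug/mL. Accordingly an at least 5.8-fold higher number from compound 2 to compound 3 (0.76 log units; beyond the scatter) and an at least 6.9-fold lower number from compound 1 to compound 2 (0.84 log units; beyond the scatter), while the two limits leave a step that the two limits leave unreadable from compound 1 to compound 3. Compound 3 thus sits at the upper edge of the numbers shown (the limit of >= 164 ug/mL in this assay, at which 1 of the 3 values shown sits). Compound 4 `CNC(=O)c1cc(C(=O)NC)c(=O)n(Cc2ccccc2)c1` is reached by hydrogen in place of methoxymethyl on a saturated chain carbon bound to an amide-type nitrogen. Among the measured compounds shown here, the only step that bears on this change is the move from cyclobutyl to 2-methoxyethyl, which was at least modest; the present change goes to a smaller group, not a ring. Compound 4 is expected to stay high, with a step about an at least 1.2-fold lower number from compound 3 to compound 4 (0.10 log units; that floor lies within the scatter). The estimate for compound 4 is 130 ug/mL (range 45 ug/mL to 250 ug/mL).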

Compound 4, solubility: >= 118 ug/mL
Compound 4: no number, only a limit (the forecaster's own chance of this, stated with the estimate: 40%); the middle value does not contradict the limit.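

Methyl in place of cyclobutyl on an amide-type nitrogen gives an at least 4.2-fold higher number from compound 2 to compound 4 (0.62 log units; beyond the scatter), so this step does not need the methoxymethyl part of the 2-methoxyethyl group. The read-out for compound 4 in this assay is a limit, >= 118 ug/mL. The steps among compound 1, compound 3 and compound 4 join two limits and cannot be read.

On these data alone, whether methyl, 2-methoxyethyl and 3-(morpholin-2-yl)propyl differ at all remains open. So does the read-out with a carboxylic acid or a longer plain alkyl chain on this nitrogen.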